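Ethyl for methyl on a shared core: an expected small step

The source may hold more compounds than are shown below. What is called first, only, known or untested is meant among the compounds shown, and "the series" means these compounds.

Measured so far in a functional assay on trachea (Cavia porcellus) for activation; on this read-out higher numbers stand for weaker inhibition and lower numbers for stronger inhibition:
- compound 1 `COc1nc(-c2ccc(F)cc2)cc(-c2ccc(Cl)cc2Cl)c1C#N`: 7430 nM
- compound 2 `CCOc1nc(-c2ccc(F)cc2)cc(-c2ccc(Cl)cc2Cl)c1C#N`: 8020 nM
- compound 3 `CN1CCN(c2nc(-c3ccc(Cl)cc3)cc(-c3ccc(Cl)cc3Cl)c2C#N)CC1`: 13000 nM

Compound 2 differs from compound 1 by methyl in place of hydrogen on a saturated chain carbon bound to an oxygen on an aromatic ring, and this gave a 1.1-fold higher number from compound 1 to compound 2 (0.03 log units; within the scatter). Compound 3 sits on a different core; the difference between the core of compound 3 and that of compound 1 is not broken down here. Compound 4 `CCN1CCN(c2nc(-c3ccc(Cl)cc3)cc(-c3ccc(Cl)cc3Cl)c2C#N)CC1` has not yet been measured in this assay. It differs from compound 3 by methyl in place of hydrogen on a saturated chain carbon bound to an amine nitrogen in a ring. This is the same kind of change as that from compound 1 to compound 2, though the place differs: there the carbon was bound to an oxygen on an aromatic ring, here it is bound to an amine nitrogen in a ring. Because a 1.1-fold higher number from compound 1 to compound 2 (0.03 log units; within the scatter) was within the scatter, compound 4 is expected to show a step of about a 1.1-fold higher number from compound 3 to compound 4 (0.03 log units; within the scatter). Compound 4 is thus estimated at 14000 nM, between 6000 nM and 32000 nM.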

Compound 4, half-maximal inhibitory concentration: 15800 nM
Compound 4: middle estimate off by 1.1-fold (0.05 log units), on the low side, within the range that was stated.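

In this assay, methyl in place of hydrogen on a saturated chain carbon bound to an amine nitrogen in a ring gave a 1.2-fold higher number from compound 3 to compound 4 (0.08 log units; within the scatter). Set beside the earlier step on the other core, the change carried over without a discernible difference: the same change on two cores in this assay, a 1.1-fold higher number (0.03 log units; within the scatter) from compound 1 to compound 2 and a 1.2-fold higher number (0.08 log units; within the scatter) from compound 3 to compound 4, 1.1-fold (0.05 log units) apart, within the scatter of two such steps. Going by these compounds alone, this shows only that the change stayed within the scatter on these two cores, each with its own place of attachment, and it does not show that the same would hold on any other core.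

The compounds shown leave open what a longer chain, such as propyl or butyl, would do in place of the ethyl. They also leave open the effect of a chain ending in a hydroxyl group or a carboxylic acid.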